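The source may hold more compounds than are shown below. What is called first, only, known or untested is meant among the compounds shown, and "the series" means these compounds.

Measured so far:
compound 1 `O=c1c([C@@H]2C[C@H](c3ccccc3)ON2c2ccccc2)coc2cc(Cl)c(Cl)cc12`: 43000 nM
compound 2 `O=c1c([C@@H]2C[C@H](c3ccccc3)ON2c2ccccc2)coc2ccc(Br)cc12`: 51000 nM

In a functional assay on A549 cells (Homo sapiens) for inhibition, read by sulforhodamine B assay, with a stated time of 48 h (on this read-out higher numbers stand for weaker inhibition and lower numbers for stronger inhibition), compound 2 gives 51000 nM and compound 1 gives 43000 nM. Within the data shown here, these two values lie within the scatter of each other, so compound 2 stands level with the only other number available, and both sit in the same narrow band.

The next compound is compound 3 `Cc1ccc2occ([C@@H]3C[C@H](c4ccccc4)ON3c3ccccc3)c(=O)c2c1`, which has methyl in place of bromo on an aromatic carbon. Among the measured compounds shown here, no measured pair shows this change, so the data give no direct guide to its size or direction. With only the closeness of the two values to go on, no step beyond the scatter is expected in this assay. The expected step is a 1.1-fold higher number from compound 2 to compound 3 (0.03 log units; within the scatter), an estimate with no firm direction. Compound 3 is estimated at 55000 nM, with an expected range from 25000 nM to 100000 nM.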

Compound 3, half-maximal inhibitory concentration: 49000 nM
The estimate for compound 3 lay 1.1-fold (0.05 log units) above the measured number, and the stated range covers the measured number.
By their numbers in this assay, from the lowest: compounds 1, 3 and 2 (each within the scatter of the next).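

In this assay, among these compounds, methyl in place of bromo on an aromatic carbon gives a 1.0-fold lower number from compound 2 to compound 3 (0.02 log units; within the scatter), the first step that isolates a single change at this position. On this read-out, the exchange of one heavy atom for another, with no ring, hydrogen-bond donor, hydrogen-bond acceptor or net charge on either group, leaves compound 3 level with compound 2. No measurement available bears on the reason for this result.

As far as these compounds go, only bromo and methyl can be compared directly here, so it remains open whether an amine, a carboxylic acid or a longer chain at this position would give a step beyond the scatter. The compounds shown also leave open how far a change elsewhere on the shared core would move the number.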